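This account rests on a few compounds, and the source may have more. Where it says the series, first, only, none or still open, it means among the compounds named here.

Measured compounds:
compound 1, `ClCc1ccc(Cn2cnc3c(Cl)ncnc32)cc1` — 4570 nM
compound 2, `ClCc1cccc(Cn2cnc3ncnc(Cl)c32)c1` — 3090 nM
compound 3, `ClCc1cccc(Cn2cnc3c(Cl)ncnc32)c1` — 36300 nM

In a functional assay on UO-31 cells (Homo sapiens) for cytotoxicity, read by sulforhodamine B assay, with a stated time of 48 h (on this read-out higher numbers stand for weaker inhibition of growth and lower numbers for stronger inhibition of growth), compound 3 gives the highest of the three numbers, beyond the scatter from both compound 1 and compound 2, so compound 3 stands as the weakest of the three here. Compound 4, `ClCc1cccc(Cn2cnc3c(Cl)nc(Cl)nc32)c1`, differs from compound 3 by chloro in place of hydrogen on an aromatic carbon on the shared core. Going by the values given here, no pair of measured compounds shows this change, so there is no directly comparable step to draw on. Compound 4 is expected to give 20000 nM, with a range from 5000 nM to 80000 nM. The step of a 1.8-fold lower number from compound 3 to compound 4 (0.26 log units; within the scatter) is expected to be modest, without a clear direction beyond the scatter.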

Compound 4, concentration for total growth inhibition: 3090 nM
For compound 4 the middle estimate is 6.5-fold (0.81 log units) above the measured one; the measured number lies below the stated range.
By their numbers in this assay, from the lowest: compounds 2, 4 and 1 (each within the scatter of the next); then compound 3.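

In this assay, chloro in place of hydrogen on the aromatic carbon between two ring nitrogen atoms gives a large step (a 12-fold lower number from compound 3 to compound 4 (1.07 log units; beyond the scatter)). The earlier compounds shown here left this position unchanged, and this step shows that one added chlorine atom there can shift the growth-inhibition number well beyond the scatter. The data shown offer no explanation for this shift. From the compounds shown here alone, it remains open whether an amine or a methoxy group on the same carbon would give a similar step, and whether chloro would do so on the core of compound 1 or compound 2.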